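The compounds below may be only part of what the source reports. "The series", "measured", "known", "first", "only" and "open" are said of these compounds alone.

Measured so far:
compound 1, `O=C(CSc1nc(Nc2ccccc2)c2ccccc2n1)Nc1ccccc1Br`, in a functional assay on MGC-803 cells (Homo sapiens) for inhibition, read by MTT assay, with a stated time of 72 h; a lower number here means a stronger inhibitor, a higher number a weaker inhibitor: 18600 nM
compound 2, `CCc1cccc(NC(=O)CSc2nc(Nc3ccccc3)c3ccccc3n2)c1`, in this assay: 15800 nM

Compound 2 sits at one end of this pair, but the step of a 1.2-fold lower number from compound 1 to compound 2 (0.07 log units; within the scatter) is within the scatter, so the two compounds cannot be told apart on these numbers. That step, 3-ethylphenyl in place of 2-bromophenyl on an amide-type nitrogen, is the only one on record, and it alters a different part of the molecule than the change now in question.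

Compound 3, `COc1cccc(NC(=O)CSc2nc(Nc3ccccc3)c3ccccc3n2)c1`, has not yet been measured. It differs from compound 2 by methoxy in place of ethyl on an aromatic carbon. Within the data shown here, no measured step concerns a methoxy group or this exact position, and the one step that exists, from compound 1 to compound 2, was within the scatter. With nothing pointing in either direction, the step expected in this assay is a 1.0-fold higher number from compound 2 to compound 3 (0.01 log units; within the scatter), that is, none beyond the scatter. Compound 3 is therefore estimated at 16000 nM, with a range from 7000 nM to 40000 nM.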

Compound 3, half-maximal inhibitory concentration: 10000 nM
Beside the measured number, compound 3's estimate is 1.6-fold (0.20 log units) above it; the range from low to high includes it.
By their numbers in this assay, from the lowest: compounds 3, 2 and 1 (each within the scatter of the next).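

In this assay, putting methoxy on this aromatic carbon, with its one hydrogen-bond acceptor where ethyl has none, gives a 1.6-fold lower number from compound 2 to compound 3 (0.20 log units; within the scatter) and so leaves compound 3 indistinguishable from compound 2 on these numbers. The comparison with the 2-bromophenyl compound reads the same way, with a 1.9-fold lower number from compound 1 to compound 3 (0.27 log units; within the scatter) as its result, so the three groups on the amide nitrogen, 2-bromophenyl, 3-ethylphenyl and 3-methoxyphenyl, cannot be told apart here, and swapping a carbon-only group for an oxygen-bearing one at this place has not yet produced a step beyond the scatter. No measurement is available that would explain these numbers.

As far as these compounds go, what stays open is whether any group on this aromatic carbon can move the number beyond the scatter, and an amine, a carboxylic acid or a longer chain there would each put that to the test. The rest of the shared core is identical in all three compounds, so nothing shown here tells how a change elsewhere in the molecule would read.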